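A few compounds are considered here, and "the series" means these few. Any claim that something is new, unique, unknown or untested is made for them only; others in the source may bear on it.

Compound 1 (`CCOC(=O)CCCCCOc1cccc(CN(C(=O)c2ccc(-c3ccco3)cc2)C(C)C)c1`), compound 2 (`CCOC(=O)CCCCCOc1cccc(CN(C(=O)c2ccc(-c3cccc(OCC)c3)cc2)C(C)C)c1`) and compound 3 (`CCOC(=O)CCCCCOc1cccc(CN(C(=O)c2ccc(-c3cc(OC)cc(OC)c3)cc2)C(C)C)c1`) share one core and differ only in one aromatic group. All three were tested in an ADME assay on BJ cells (Homo sapiens) for cytotoxicity, read by CellTiter-Glo and resazurin assay, with a stated time of 72 h (a higher number here means that more compound is needed for the effect, a lower number that less compound is needed), and none gave an exact number. Compound 1 gives > 26000 nM as a limit and not a number. Compound 2 gives > 22300 nM as a limit too. Compound 3 gives > 26000 nM as a limit as well, so it has no exact place among the three.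

Compound 4 (`CCOC(=O)CCCCCOc1cccc(CN(C(=O)c2ccc(-c3cccc(F)c3)cc2)C(C)C)c1`) carries 3-fluorophenyl in place of 3,5-dimethoxyphenyl on an aromatic carbon. Three measured swaps of this same group bear on the change (a step that the two limits leave unreadable from compound 1 to compound 2; a step that the two limits leave unreadable from compound 1 to compound 3; a step that the two limits leave unreadable from compound 2 to compound 3) and give no size or direction. The expected change is therefore none beyond the scatter (a number no higher from compound 3 to compound 4 (the limit leaves the size open)), and this assay will probably report only a limit again. For compound 4 the estimate is 26000 nM with 13000 nM to 40000 nM as the expected range.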

Compound 4, half-maximal effective concentration: > 26000 nM
Compound 4: only a limit was reported; the forecaster's own chance of this, stated with the estimate: 85%; the middle value sits exactly at the limit.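

Compound 4, like compound 1, compound 2 and compound 3, gives only a limit in this assay, so no step among these four compounds can be read. The compounds shown leave open what concentration of each one produces the effect, and whether swapping the aromatic group changes it.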